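A Sulfolane Ring Replaces Isopropyl on the Shared Core

A few compounds are considered here, and "the series" means these few. Any claim that something is new, unique, unknown or untested is made for them only; others in the source may bear on it.

Compound 1, `Cc1cc(NC(=S)Cn2nnc(-c3ccccc3)n2)n(C2CCCCC2)n1`: 623 nM
Compound 2, `Cc1cc(NC(=O)Cn2nnc(-c3ccccc3)n2)n(C(C)C)n1`: 556 nM

In an assay on HEK293 cells for activation of Kir3.1/Kir3.2 (Homo sapiens), read by thallium flux (a lower number here means that less compound is needed, a higher number that more compound is needed for the effect), compound 2 gives 556 nM, the lower of the two numbers shown so far; compound 1 gives 623 nM, and the gap between the two lies within the scatter, so neither can be called the stronger. Compound 3, `Cc1cc(NC(=O)Cn2nnc(-c3ccccc3)n2)n(C2CCS(=O)(=O)C2)n1`, keeps the shared core of compound 2 and changes a single place: 1,1-dioxothiolan-3-yl in place of isopropyl on an aromatic nitrogen. Within the data shown here, no step between two measured compounds isolates a change of this kind, so the expectation rests only on the two values shown and on the size of the group that enters. In this assay a step toward a higher number is expected, estimated at a 1.6-fold higher number from compound 2 to compound 3 (0.21 log units; within the scatter), modest enough that it may not clearly exceed the scatter. Compound 3 is estimated at 900 nM, within a range from 300 nM to 3000 nM.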

Compound 3, half-maximal effective concentration: 1030 nM
Compound 3: middle estimate off by 1.1-fold (0.06 log units), on the low side; low and high end bracket the measured number.
By their numbers in this assay, from the lowest: compounds 2, 1 and 3 (each within the scatter of the next).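

On an aromatic nitrogen of the shared core, a much larger group can replace isopropyl without a clear loss: in this assay the change to 1,1-dioxothiolan-3-yl gives a 1.9-fold higher number from compound 2 to compound 3 (0.27 log units; within the scatter) and so cannot be told apart from no change. Among these compounds, the entering group brings a non-aromatic ring, 7 heavy atoms in place of 3, and 2 hydrogen-bond acceptors where isopropyl has 0, so this is the first direct view of this position. No measurement here accounts for the size of the step or ties it to one feature of the new group.

Going by these compounds, whether the ring or its two oxygens matter more remains open, and a plain cyclopentyl ring on the same nitrogen would separate the two. Equally open, on these data alone, is how this position responds to a chain ending in an amine or a carboxylic acid.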